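Weak Binders and One Untested Swap at the Ether Oxygen

The compounds below may be only part of what the source reports. "The series", "measured", "known", "first", "only" and "open" are said of these compounds alone.

Measured so far in an assay on isolated protein for activation of cGMP-dependent protein kinase 1 (Homo sapiens), read by ADP-Glo, with stated times of 30 min and 2 h; a lower number here means that less compound is needed, a higher number that more compound is needed for the effect:
Compound 1 `COc1cccc([C@@H](CO)O[C@H]2CCCN(Cc3ccc(C(=O)O)cc3C)[C@H]2c2ccccc2)c1` shows only the limit > 200000 nM.
Compound 2 `Cc1cc(C(=O)O)ccc1CN1CC[C@H](OC(CO)c2cc(Cl)cc(Cl)c2)[C@@H]1c1ccccc1` gives 185000 nM.
Compound 3 `Cc1cc(C(=O)O)ccc1CN1C(C)CC[C@H](O[C@H](CO)c2cc(Cl)cc(Cl)c2)[C@@H]1c1ccccc1` gives 130000 nM.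

All three values lie at the very top of what this assay can report. Compound 1 stands at the edge: its result is a limit, not a number, as the limit of > 200000 nM in this assay, at which 1 of the 3 values shown sits, records, so it can only be said that compound 1 needs more compound than the assay could test. Compound 4 `Cc1cc(C(=O)O)ccc1CN1CCC[C@H](OC(c2cc(Cl)cc(Cl)c2)C(C)O)[C@@H]1c1ccccc1` differs from compound 1 by a group of 12 heavy atoms (9 carbon, 1 oxygen, 2 chlorine; one six-membered aromatic ring of carbon only) in place of a group of 11 heavy atoms (9 carbon, 2 oxygen; one six-membered aromatic ring of carbon only), on an oxygen on a saturated carbon. Among the measured compounds shown here, no step between two measured compounds is known here, so the expectation rests on the spread of the values: compound 2 gives 185000 nM and compound 3 gives 130000 nM, both within the scatter of each other and near the top of what this assay can report. The step from compound 1 to compound 4 in this assay is expected to be small, if any, toward a barely measurable value, as an at least 1.3-fold lower number from compound 1 to compound 4 (0.12 log units; that floor lies within the scatter). Compound 4 is therefore estimated at 150000 nM, with a range from 60000 nM to 400000 nM, and a real chance that only a limit is reported.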

Compound 4, half-maximal effective concentration: > 196000 nM
Compound 4 ended at the assay's limit; the forecaster's own chance of this, stated with the estimate: 40%; middle value at least 1.3-fold (0.11 log units) away from the limit.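

Among the compounds shown here, compound 1 and compound 4 each end at a limit of the assay, not a number, so no step between them can be read. The compounds shown leave open whether the group of 12 heavy atoms, in place of the group of 11 heavy atoms, changes the amount of compound needed.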